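Hydroxamate chain extension on two fused bicyclic cores

The compounds below may be only part of what the source reports. "The series", "measured", "known", "first", "only" and "open" are said of these compounds alone.

Compound 3 `Nc1ncnc2c1c(-c1cnc3[nH]ccc3c1)nn2CCCCCCC(=O)NO` gives 9860 nM in a functional assay on HCT-116 cells (Homo sapiens) for inhibition, read by MTT assay, with a stated time of 72 h; a lower number here means a stronger inhibitor, a higher number a weaker inhibitor. Compound 1 `Nc1ncnc2c1c(-c1cnc3[nH]ccc3c1)nn2CCCCCCCCC(=O)NO` gives 5460 nM in this assay. The two differ by 2-(hydroxycarbamoyl)ethyl in place of hydroxycarbamoyl on a saturated chain carbon, six bonds along the chain from an aromatic nitrogen and the step reads a 1.8-fold lower number from compound 3 to compound 1 (0.26 log units; within the scatter). Compound 2 `Nc1nc2cc(-c3nn(CCC(=O)NO)c4ncnc(N)c34)ccc2o1` carries a different core; how it differs from the core of compound 3 is not broken down here. In this assay compound 2 reaches only a limit, > 100000 nM, which is the limit of > 100000 nM in this assay, at which 1 of the 3 values shown sits. Compound 4 `Nc1nc2cc(-c3nn(CCCCC(=O)NO)c4ncnc(N)c34)ccc2o1` is not yet measured; it differs from compound 2 by 2-(hydroxycarbamoyl)ethyl in place of hydroxycarbamoyl on a saturated chain carbon, two bonds along the chain from an aromatic nitrogen. This is the same kind of change as that from compound 3 to compound 1, but the place is not the same: two bonds along the chain from an aromatic nitrogen here, six bonds there. Among the measured compounds shown here, the only measured example of this change, on the other core, sits within the scatter, and compound 2 offers a limit rather than a number, so the expectation rests weakly on it. The expected step is an at least 1.6-fold lower number from compound 2 to compound 4 (0.22 log units; that floor lies within the scatter). Compound 4 is estimated at 60000 nM in this assay, between 15000 nM and 300000 nM.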

Compound 4, half-maximal inhibitory concentration: 34000 nM
For compound 4 the middle estimate is 1.8-fold (0.25 log units) above the measured one; the range from low to high includes it.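

In this assay, 2-(hydroxycarbamoyl)ethyl in place of hydroxycarbamoyl on the core of compound 2, on a saturated chain carbon two bonds along the chain from an aromatic nitrogen, gives an at least 2.9-fold lower number from compound 2 to compound 4 (0.46 log units; beyond the scatter). Set beside the same kind of change at six bonds along the chain on the other core, this gives no measured difference between the two cores: the same change on two cores in this assay, a 1.8-fold lower number (0.26 log units; within the scatter) from compound 3 to compound 1 and an at least 2.9-fold lower number (0.46 log units; beyond the scatter) from compound 2 to compound 4; the limit leaves it open whether they differ. The comparison stays open-ended, since compound 2 stands at a limit of the assay and not at a number: the limit of > 100000 nM in this assay, at which 1 of the 4 values shown sits.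

With one step on each core, at different places along the chain, the compounds shown give no rule for carrying this change from one core to another. Open, on these data alone, is whether a longer chain on the core of compound 4 would lower the number further, and whether a carboxylic acid in place of hydroxycarbamoyl would keep any of the inhibition on either core.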